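Amide Substituent Changes on the Shared Core: Benzyl Next

This account rests on a few compounds, and the source may have more. Where it says the series, first, only, none or still open, it means among the compounds named here.

Compound 2 `CCCn1c(SCc2cc([N+](=O)[O-])ccc2OC)nc2cc(NC(=O)NC(C)(C)C)cc(C(=O)NC(C)(C)C)c21` carries a tert-butyl group on its amide-type nitrogen, and in an assay on isolated protein for inhibition of Gonadotropin-releasing hormone receptor (Homo sapiens) (on this read-out higher numbers stand for weaker inhibition and lower numbers for stronger inhibition), compound 2 gives 410 nM. Of the two measured values this is the highest. Its nearest neighbour is compound 1 `CCCn1c(SCc2cc([N+](=O)[O-])ccc2OC)nc2cc(NC(=O)NC(C)(C)C)cc(C(=O)NC)c21`, which in this assay gives 41 nM; the change between them, tert-butyl in place of methyl on an amide-type nitrogen, reads a 10-fold higher number from compound 1 to compound 2 (1.00 log units; beyond the scatter).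

Compound 3 `CCCn1c(SCc2cc([N+](=O)[O-])ccc2OC)nc2cc(NC(=O)NC(C)(C)C)cc(C(=O)NCc3ccccc3)c21` has not yet been measured. It differs from compound 2 by a single change: benzyl in place of tert-butyl on an amide-type nitrogen. Within the data shown here, only one measured step touches this nitrogen, a 10-fold higher number from compound 1 to compound 2 (1.00 log units; beyond the scatter), and it shows that the move from methyl to tert-butyl weakened inhibition well beyond the scatter. Benzyl is a different kind of group, and no measured pair shows what a ring on this nitrogen does. Going by these compounds, a further move in the same direction and no move beyond the scatter both remain open, so the expectation sits close to the value of compound 2 with a wide range. For compound 3 the expected step is a 1.2-fold higher number from compound 2 to compound 3 (0.09 log units; within the scatter). The estimate for compound 3 is 500 nM, with a range from 120 nM to 2000 nM.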

Compound 3, half-maximal inhibitory concentration: 120 nM
For compound 3 the middle estimate is 4.2-fold (0.62 log units) above the measured one, and the stated range covers the measured number.
By their numbers in this assay, from the lowest: compound 1; then compound 3; then compound 2.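

In this assay, benzyl in place of tert-butyl on the amide-type nitrogen gives a 3.4-fold lower number from compound 2 to compound 3 (0.53 log units; beyond the scatter), so this nitrogen does not simply penalise more heavy atoms: benzyl carries more of them than tert-butyl, yet compound 3 gives the lower number. Among these compounds, the single earlier step could have been read as a steady loss with growing substituents, and compound 2 now stands against that reading. Benzyl does not recover the level of the methyl amide, however, as a 2.9-fold higher number from compound 1 to compound 3 (0.47 log units; beyond the scatter) places compound 3 between the other two, and nothing available here accounts for this order.

The compounds shown leave open whether the improvement over compound 2 goes with the aromatic ring or with the unbranched carbon bound to the nitrogen, a question on which cyclohexylmethyl, isopropyl or a longer straight chain such as n-propyl would bear. Also open, going by these compounds, are what the unsubstituted primary amide would give at this nitrogen, and whether a methoxy group or a chlorine on the benzyl ring, or a longer phenethyl link, would move the number towards that of compound 1.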